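Difluoroethyl in Place of Trifluoromethyl: Clearance Outlook

The source may hold more compounds than are shown below. What is called first, only, known or untested is meant among the compounds shown, and "the series" means these compounds.

Of the compounds shown here, three built on one shared core have been tested in an in vitro ADME assay on microsomes from liver (Homo sapiens) for metabolic stability; on this read-out higher numbers stand for fast clearance and lower numbers for slow clearance. Compound 1 has the structure `CCC(F)(F)c1nc2nc(C)cc(Nc3ccc(S(F)(F)(F)(F)F)cc3)n2n1`. In this assay compound 1 gives < 5 mL.min-1.g-1, which is a limit of the assay and not a number. Compound 2 has the structure `CCOc1nc2nc(C)cc(Nc3ccc(S(F)(F)(F)(F)F)cc3)n2n1`. In this assay compound 2 gives < 5 mL.min-1.g-1, again a limit. Compound 3 has the structure `Cc1cc(Nc2ccc(S(F)(F)(F)(F)F)cc2)n2nc(C(F)(F)F)nc2n1`. In this assay compound 3 gives < 5 mL.min-1.g-1, also a limit. Compound 3 therefore stands where every result so far stands, at the limit of < 5 mL.min-1.g-1 in this assay, at which 3 of the 3 values shown sit, and none of the three changes among these compounds can be sized: a step that the two limits leave unreadable from compound 1 to compound 2, a step that the two limits leave unreadable from compound 1 to compound 3, and a step that the two limits leave unreadable from compound 2 to compound 3.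

Compound 4, with the structure `Cc1cc(Nc2ccc(S(F)(F)(F)(F)F)cc2)n2nc(C(C)(F)F)nc2n1`, differs from compound 3 by methyl in place of fluoro on a saturated chain carbon bound to an aromatic carbon and two fluorine atoms. Among the measured compounds shown here, the only measured change at this same carbon is a step that the two limits leave unreadable from compound 1 to compound 3, which is unreadable, so no direction and no size can be taken from it; nothing measured points to a move away from the limit.

Compound 4 is therefore expected to give about 4 mL.min-1.g-1 in this assay, within a range from 2 mL.min-1.g-1 to 9 mL.min-1.g-1. The expected step is a step that the limit leaves unreadable from compound 3 to compound 4, most likely again reported only as a limit.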

Compound 4, intrinsic clearance in microsomes in the Homo sapiens assay: < 5 mL.min-1.g-1
Compound 4: only a limit was reported; the forecaster's own chance of this, stated with the estimate: 75%; the middle value does not contradict the limit.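

Compound 4 sits at the same limit as compounds 1, 2 and 3, so no step among these four compounds can be read in the Homo sapiens assay: the limit of < 5 mL.min-1.g-1 in the Homo sapiens assay, at which 4 of the 4 values shown sit.

In a physicochemical assay for lipophilicity, at pH 7.4 (a lower number here means a more polar compound, a higher number a more lipophilic compound), compound 3 gives 3.7 and compound 4 gives 3.6, two values within the usual scatter of each other.

The compounds shown leave open how clearance differs among these four compounds, if it differs at all.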